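Swapping a Methylpyridinyl Arm for Pyrazolyl: Cytotoxicity Outlook

The source may hold more compounds than are shown below. What is called first, only, known or untested is meant among the compounds shown, and "the series" means these compounds.

Compound 1 `Cc1ccc(-c2ccc3[nH]c(=O)nc(-c4ccccc4)c3c2)cn1` was examined in an ADME assay on THP-1 cells (Homo sapiens) for cytotoxicity, read by MTT assay, with a stated time of 72 h; on this read-out higher numbers stand for an effect only at larger amounts of compound and lower numbers for an effect already at smaller amounts. There compound 1 gives only a limit of the assay, > 50000 nM. Its two measured neighbours differ from it in a single place. Compound 2 `Cc1ccncc1-c1ccc2[nH]c(=O)nc(-c3ccccc3)c2c1` also reaches only a limit, > 50000 nM. Compound 3 `O=c1nc(-c2ccccc2)c2cc(-c3ccccc3)ccc2[nH]1` likewise stops at a limit, > 50000 nM. The steps a step that the two limits leave unreadable from compound 1 to compound 2, a step that the two limits leave unreadable from compound 1 to compound 3 and a step that the two limits leave unreadable from compound 2 to compound 3 therefore cannot be given a size; what the numbers do show is the limit of > 50000 nM in this assay, at which 3 of the 3 values shown sit. Compound 1 thus stands together with every measured compound at that same limit, without any readable spread among them.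

Compound 4 `O=c1nc(-c2ccccc2)c2cc(-c3cc[nH]n3)ccc2[nH]1` differs from compound 1 in one exchange: 1H-pyrazol-3-yl in place of 6-methylpyridin-3-yl on an aromatic carbon. All three measured steps bear on this, since each replaces the group at this same place, and none gave a readable size. No step beyond the scatter is expected in this assay, in either direction. Compound 4 is therefore expected to remain at the limit as well, with an estimated step that the limit leaves unreadable from compound 1 to compound 4. The estimate for compound 4 is 60000 nM, within a range of 30000 nM to 150000 nM, most likely reported once more as a limit rather than a number.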

Compound 4, half-maximal effective concentration: > 50000 nM
Compound 4: only a limit was reported (the forecaster's own chance of this, stated with the estimate: 85%); the middle value does not contradict the limit.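

The steps joining compound 4 to compound 1, compound 2 and compound 3 cannot be read, since all four compounds end at one limit: the limit of > 50000 nM in this assay, at which 4 of the 4 values shown sit. In this assay the compounds shown leave open whether the four arms differ at all, and at what amount any of them would show cytotoxicity.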